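This account rests on a few compounds, and the source may have more. Where it says the series, first, only, none or still open, it means among the compounds named here.

In an ADME assay on microsomes from liver (Canis lupus familiaris) for metabolic stability (on this read-out lower numbers stand for a shorter-lived compound and higher numbers for a longer-lived compound), compound 1 `Nc1nc(NCCNc2ncc(-c3ncc[nH]3)c(-c3ccc(Cl)cc3F)n2)ccc1[N+](=O)[O-]` gives > 0.5 h, which is a limit of the assay and not a number. Compound 2 `Nc1nc(NCCNc2ncc(-c3ncc[nH]3)c(-c3ccc(Br)cc3F)n2)ccc1[N+](=O)[O-]` gives > 0.5 h, which is also a limit. Compound 2 therefore has no exact half-life to start from, and the evidence so far amounts to the limit of > 0.5 h in this assay, at which 2 of the 2 values shown sit.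

The next compound, compound 3 `Nc1nc(NCCNc2ncc(-c3ncc[nH]3)c(-c3cc(F)c(Cl)cc3Cl)n2)ccc1[N+](=O)[O-]`, has not yet been measured. It differs from compound 2 by 2,4-dichloro-5-fluorophenyl in place of 4-bromo-2-fluorophenyl on an aromatic carbon, ortho to a 1H-imidazol-2-yl group.

Within the data shown here, only one measured step bears on this change, a step that the two limits leave unreadable from compound 1 to compound 2, with bromo in place of chloro on an aromatic carbon. Its size and direction cannot be read, so it offers no measured effect to carry forward. With so little to go on, no shift beyond the usual scatter is expected in this assay, and no direction is favoured. The expected change is a step that the limit leaves unreadable from compound 2 to compound 3. Compound 3 is expected at about 0.6 h, with an estimated range from 0.3 h to 1.2 h.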

Compound 3, half-life: > 0.5 h
Compound 3: a limit, no number; the forecaster's own chance of this, stated with the estimate: 70%; the middle value lies beyond the limit too.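

Compound 3 gives > 0.5 h, which is a limit of the assay and not a number. Compound 1 and compound 2 also stand at limits, so no step among these three compounds can be read in this assay. Still open are their exact half-lives and whether either change of the phenyl group shifts them at all: the limit of > 0.5 h in this assay, at which 3 of the 3 values shown sit.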